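Removing the benzyl substituents from compound 2

The source may hold more compounds than are shown below. What is called first, only, known or untested is meant among the compounds shown, and "the series" means these compounds.

Measured in a functional assay on PC-3 cells (Homo sapiens) for antiproliferative activity, read by MTT assay, with a stated time of 48 h; a higher number here means a weaker inhibitor, a lower number a stronger inhibitor:
- compound 1 `COc1ccc(CN(C(=O)CSc2nc3ccccc3s2)c2cc(OC)c(OC)c(OC)c2)cc1C`: 34300 nM
- compound 2 `COc1ccc(CN(C(=O)CSc2nc3ccccc3s2)c2cc(OC)c(OC)c(OC)c2)cc1O`: 2110 nM
- compound 3 `COc1ccc(CN(C(=O)CSc2nc3cc(Cl)ccc3s2)c2cc(OC)c(OC)c(OC)c2)cc1O`: 11200 nM

Compound 2 has the lowest number of the three at 2110 nM, and its gaps to the other two lie beyond the scatter. The next compound to be measured is compound 4 `COc1cc(N(Cc2ccccc2)C(=O)CSc2nc3ccccc3s2)cc(OC)c1OC`. Its change from compound 2 is phenyl in place of 3-hydroxy-4-methoxyphenyl on a saturated chain carbon bound to an amide-type nitrogen.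

The closest guide is a 16-fold lower number from compound 1 to compound 2 (1.21 log units; beyond the scatter), a large step with hydroxy in place of methyl on an aromatic carbon. Compound 4 also has no hydroxy, so compound 2 may lose the advantage it holds over compound 1 in that step. Going by the values given here, the guide is incomplete, since compound 1 keeps a methyl and a methoxy group that compound 4 does not carry, and no measured compound has a bare phenyl here. The other measured step, a 5.3-fold higher number from compound 2 to compound 3 (0.72 log units; beyond the scatter), involves a chloro change and says little about this one.

A rise in this assay is expected, of moderate size and with wide uncertainty. The expected change is a 3.8-fold higher number from compound 2 to compound 4 (0.58 log units; beyond the scatter). For compound 4 the estimated value is 8000 nM, with an expected range of 2500 nM to 28000 nM.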

Compound 4, half-maximal inhibitory concentration: 54100 nM
Compound 4: middle estimate off by 6.8-fold (0.83 log units), on the low side, and the stated range ends below it.
By their numbers in this assay, from the lowest: compound 2; then compound 3; then compounds 1 and 4 (each within the scatter of the next).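

In this assay, the group on the saturated chain carbon bound to an amide-type nitrogen proves to be a strong determinant of the read-out: a 26-fold higher number from compound 2 to compound 4 (1.41 log units; beyond the scatter), a large step for cutting 3-hydroxy-4-methoxybenzyl back to benzyl. The second new step adds what the earlier compounds could not show, namely that phenyl and 4-methoxy-3-methylphenyl at this place are not separated, with a 1.6-fold higher number from compound 1 to compound 4 (0.20 log units; within the scatter), so among these two-way comparisons the lower number goes with 3-hydroxy-4-methoxyphenyl in compound 2 and not with ring substitution as such. No measurement at hand accounts for either step.

Open, as far as these compounds go, is whether 3-hydroxyphenyl alone would keep the number of compound 2, or whether the 4-methoxy group must accompany the hydroxy, as a 4-methoxyphenyl counterpart would also help to show. Equally open, from the compounds shown here alone, is whether an amine or a carboxylic acid in the place of the hydroxy would give a low number in this assay, or whether only the hydroxy does so on this ring.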